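Isopropyl Gives Way to Methyl: What to Expect

The source may hold more compounds than are shown below. What is called first, only, known or untested is meant among the compounds shown, and "the series" means these compounds.

Measured so far in a physicochemical assay for metabolic stability, in simulated intestinal fluid, with a stated time of 15 min, tested at 4 uM; a lower number here means that less of the compound is left, a higher number that more of the compound is left:
- compound 1 `COC[C@H](NC(=O)c1cc(C)on1)C(=O)N[C@@H](COC)C(=O)N[C@@H](CC(C)C)C(=O)[C@@]1(C)CO1` gives 70%
- compound 2 `COC[C@H](NC(=O)c1cc(C)on1)C(=O)N[C@H](C(=O)N[C@@H](CC(C)C)C(=O)[C@@]1(C)CO1)C(C)C` gives 95%

Of these two numbers, compound 2 holds the higher, with 95%. The next molecule, compound 3 `COC[C@H](NC(=O)c1cc(C)on1)C(=O)N[C@@H](C)C(=O)N[C@@H](CC(C)C)C(=O)[C@@]1(C)CO1`, differs from compound 2 in one place: methyl in place of isopropyl on a saturated chain carbon bound to an amide-type nitrogen and a carbonyl carbon. In words, this is methyl in place of isopropyl on a saturated chain carbon bound to an amide-type nitrogen and a carbonyl carbon.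

For the measured compounds named here, one measured step bears on this change, because it concerns the same place: a number 25 percentage points higher from compound 1 to compound 2 (beyond the scatter). There, isopropyl took the place of methoxymethyl, and the step was modest but beyond the scatter. Compound 1, which lacks isopropyl at this place, gives 70%, so a lower number is also expected for compound 3. Going by the values given here, no measured compound carries methyl here, so this expectation rests on a single step and stays uncertain. The expected change is a number 23 percentage points lower from compound 2 to compound 3 (beyond the scatter), similar in size to the measured step. For compound 3 the estimated value in this assay is 72%, with an expected range from 48% to 93%.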

Compound 3, percent of the compound remaining: 100%
For compound 3 the middle estimate is 28 percentage points below the measured one; measured number above the stated range.
By their numbers in this assay, from the lowest: compound 1; then compounds 2 and 3 (each within the scatter of the next).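

In this assay, swapping isopropyl for methyl on this saturated chain carbon gives a number 5 percentage points higher from compound 2 to compound 3 (within the scatter) and so leaves the read-out unchanged within the usual scatter, which means that isopropyl is not required at this place and that a single carbon serves just as well here. The comparison with methoxymethyl now has two sides, since hydrogen in place of methoxy gives a number 30 percentage points higher from compound 1 to compound 3 (beyond the scatter) and compound 1 stands apart from both compound 2 and compound 3, making it the only one of the three with less of the compound left. Among these three compounds, then, the dividing line at this place runs between methoxymethyl on one side and the two plain carbon groups, isopropyl and methyl, on the other, and nothing measured here explains that division.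

Still open, on these data alone, is how this place would respond to a group of another kind, such as an amine or a carboxylic acid, or to a longer chain such as butyl. As far as these compounds go, the second methoxymethyl group stays the same in all three compounds, so what it contributes to this read-out also remains unknown.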